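From Compound 2 to Compound 4 in 5-Lipoxygenase Inhibition

The compounds below may be only part of what the source reports. "The series", "measured", "known", "first", "only" and "open" are said of these compounds alone.

Of the compounds shown here, three with a shared core have been measured in an assay on RBL-1 cells for inhibition of Polyunsaturated fatty acid 5-lipoxygenase (Rattus norvegicus); on this read-out lower numbers stand for stronger inhibition and higher numbers for weaker inhibition. Compound 1 `CN(O)/C=C\C(=O)c1ccc([N+](=O)[O-])cc1` gives 1500 nM. Compound 2 `CN(O)/C=C\C(=O)c1ccc(Cl)cc1` gives 550 nM, the lowest number of the three. Compound 3 `CN(O)/C=C\C(=O)c1ccc(F)cc1` gives 5000 nM. Every measured step concerns the aromatic carbon: a 2.7-fold lower number from compound 1 to compound 2 (0.44 log units; beyond the scatter), a 3.3-fold higher number from compound 1 to compound 3 (0.52 log units; beyond the scatter) and a 9.1-fold higher number from compound 2 to compound 3 (0.96 log units; beyond the scatter). Compound 4 `O=C(/C=C\N(O)Cc1ccccc1)c1ccc(Cl)cc1` differs from compound 2 elsewhere: phenyl in place of hydrogen on a saturated chain carbon bound to an amine nitrogen. Among the compounds with values here, none of the measured steps touches that part of the molecule, so they offer no guide to this change. The expected step is a 1.4-fold lower number from compound 2 to compound 4 (0.14 log units; within the scatter), small enough that it may not reach beyond the scatter. Compound 4 is therefore estimated at 400 nM, within a range from 100 nM to 1600 nM.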

Compound 4, half-maximal inhibitory concentration: 1500 nM
Compound 4: the middle estimate sits 3.8-fold (0.57 log units) below what was measured, and the stated range covers the measured number.
By their numbers in this assay, from the lowest: compound 2; then compounds 1 and 4 (each within the scatter of the next); then compound 3.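

On this assay the change of hydrogen to phenyl on a saturated chain carbon bound to an amine nitrogen gives a 2.7-fold higher number from compound 2 to compound 4 (0.44 log units; beyond the scatter) and so weakens inhibition. This shows that the number responds to a change outside the aromatic carbon, and that compound 4 keeps measurable inhibition with the added phenyl. Nothing available accounts for this shift. On these data alone, whether a carboxylic acid, an amine or a longer chain at this carbon would lower the number remains open. So does whether phenyl has the same effect with fluoro or nitro in place of chloro on the aromatic carbon.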